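A few compounds are considered here, and "the series" means these few. Any claim that something is new, unique, unknown or untested is made for them only; others in the source may bear on it.

Measured so far:
compound 1, `Cc1cc(O)c(C(C)C)cc1-c1cc(-c2ccccc2)c(C#N)c(=O)[nH]1`: 29%
compound 2, `Cc1cc(O)c(C(C)C)cc1-c1cc(-c2ccco2)c(C#N)c(=O)[nH]1`: 42.5%

In a functional assay for inhibition, tested at 40 ug/mL (on this read-out higher numbers stand for a stronger effect at the one concentration tested and lower numbers for a weaker effect), compound 1 gives 29%, while compound 2 gives 42.5%. Within the data shown here, the one measured step, a number 13.5 percentage points higher from compound 1 to compound 2 (beyond the scatter), came from furan-2-yl in place of phenyl on an aromatic carbon. Among the measured compounds shown here, compound 2 therefore stands highest of the two numbers, and compound 1 is its only neighbour, lower by a step beyond the scatter.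

Compound 3, `Cc1cc(O)c(C(C)C)cc1-c1cc(-c2ccc(N(C)C)cc2)c(C#N)c(=O)[nH]1`, differs from compound 2 in one place: 4-(dimethylamino)phenyl in place of furan-2-yl on an aromatic carbon. The measured step bears on this only in part: it shows that a six-membered carbon ring at this position gave a lower number than furan-2-yl, so a return to a phenyl-type ring would, on that step alone, be expected to cost something. For the measured compounds named here, no measured compound carries a dimethylamino group, so its contribution is unknown. In this assay a modest downward step is expected, a number 7.5 percentage points lower from compound 2 to compound 3 (within the scatter), possibly small enough to sit within the scatter. Compound 3 is estimated at 35%, with a range from 15% to 55%.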

Compound 3, a percentage reported as inhibition, at one concentration (the size of the read-out at that concentration, not a potency): 43%
Compound 3: the middle estimate sits 8 percentage points below what was measured, within the range that was stated.
By their numbers in this assay, from the lowest: compound 1; then compounds 2 and 3 (each within the scatter of the next).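

In this assay, 4-(dimethylamino)phenyl in place of furan-2-yl gives a number 0.5 percentage points higher from compound 2 to compound 3 (within the scatter), so the two groups cannot be told apart at this position, and a six-membered aromatic ring of carbon only does not by itself mean a lower number here. Dimethylamino in place of hydrogen on the phenyl ring gives a number 14 percentage points higher from compound 1 to compound 3 (beyond the scatter), which shows that a single added group on that ring can make up the shortfall plain phenyl showed against furan-2-yl, even though the two rings differ in size and in their atoms. No supporting data explain why dimethylamino has this effect, or why two such different groups give matching numbers.

Going by these compounds, it remains open whether the rise belongs to dimethylamino itself or would also appear with a methoxy group, a primary amine or a carboxylic acid in the same place on the phenyl ring. Also open, on these data alone, is whether a larger substituted furan-2-yl, or a pyridine ring at this position, would go beyond the level shared by these two compounds, and each number here describes one concentration only, not a potency.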